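Nitrofurazan hexyl succinate amides: para-methoxy replacing para-bromo

This account rests on a few compounds, and the source may have more. Where it says the series, first, only, none or still open, it means among the compounds named here.

Measured compounds in a functional assay on HOS cells (Homo sapiens) for inhibition, read by MTT assay, with a stated time of 72 h; on this read-out lower numbers stand for stronger inhibition and higher numbers for weaker inhibition:
- compound 1 `O=C(O)CCC(=O)OCCCCCCSc1ccc([N+](=O)[O-])c2nonc12`: 8740 nM
- compound 2 `O=C(CCC(=O)OCCCCCCSc1ccc([N+](=O)[O-])c2nonc12)Nc1ccccc1Cl`: 335000 nM
- compound 3 `O=C(CCC(=O)OCCCCCCSc1ccc([N+](=O)[O-])c2nonc12)Nc1ccc(Br)cc1`: 2160 nM

Compound 3 gives the lowest number of the three in this assay. Its nearest neighbour is compound 1, and the gap between them is a 4.0-fold lower number from compound 1 to compound 3 (0.61 log units; beyond the scatter). Compound 2 is far off: a 160-fold lower number from compound 2 to compound 3 (2.19 log units; beyond the scatter).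

The next compound is compound 4 `COc1ccc(NC(=O)CCC(=O)OCCCCCCSc2ccc([N+](=O)[O-])c3nonc23)cc1`. It differs from compound 3 in one place: methoxy in place of bromo on an aromatic carbon. The same difference, cut one bond further out, reads 4-bromophenyl to 4-methoxyphenyl.

Among the measured compounds shown here, no measured step changes a substituent on the anilide ring while keeping it in the same place. The measured steps bear only indirectly: a 38-fold higher number from compound 1 to compound 2 (1.58 log units; beyond the scatter) and a 4.0-fold lower number from compound 1 to compound 3 (0.61 log units; beyond the scatter) show that the anilide part of the molecule matters strongly, and a 160-fold lower number from compound 2 to compound 3 (2.19 log units; beyond the scatter) shows that a change on that ring can move this assay by a large amount. With the substituent remaining para to a large group and only its identity changing, a modest step is expected for compound 4, more likely towards a higher number, estimated as a 2.1-fold higher number from compound 3 to compound 4 (0.32 log units; beyond the scatter). For compound 4 the expected value in this assay is therefore 4500 nM, within a range from 1000 nM to 25000 nM.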

Compound 4, half-maximal inhibitory concentration: 1800 nM
For compound 4 the middle estimate is 2.5-fold (0.40 log units) above the measured one; the measured number falls inside the stated range.
By their numbers in this assay, from the lowest: compounds 4 and 3 (each within the scatter of the next); then compound 1; then compound 2.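

In this assay, methoxy in place of bromo, para to a large group, gives a step within the scatter (a 1.2-fold lower number from compound 3 to compound 4 (0.08 log units; within the scatter)), so this position accepts either substituent, including the one that brings a hydrogen-bond acceptor and one more heavy atom, with no readable change. Compound 4 also keeps the anilide series' split: it lies a modest step from the acid (a 4.9-fold lower number from compound 1 to compound 4 (0.69 log units; beyond the scatter)) and a large step from the 2-chlorophenyl amide (a 190-fold lower number from compound 2 to compound 4 (2.27 log units; beyond the scatter)), and compound 2 goes against any rule that anilides lower the number. No measured evidence bears on this result.

Still open, on these data alone, is whether the high number of compound 2 follows from the place of its halogen or from chlorine itself, which 4-chlorophenyl or 2-bromophenyl amides would separate. Also open, as far as these compounds go, is how an amine or a carboxylic acid would fare at this position.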